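Methyl on the Core and Cytotoxicity in Kidney Cells

The source may report more compounds than this note shows. Statements on the series, on what has been measured and on what is new or still open speak of the compounds shown alone.

Three compounds have been measured in an ADME assay on HEK-293T cells (Homo sapiens) for cytotoxicity, read by CCK-8 assay, with a stated time of 48 h; a higher number here means a weaker inhibitor, a lower number a stronger inhibitor:

Compound 1 `Cc1ccc(-c2ccsc2S(=O)(=O)NCCNC(=O)Nc2cc(C(F)(F)F)cc(C(F)(F)F)c2)c(Oc2ccc(O)c(O)c2)c1` gives > 20000 nM, which is a limit of the assay and not a number.
Compound 2 `O=C(NCCNS(=O)(=O)c1sccc1-c1ccccc1Oc1ccc(O)c(O)c1)Nc1cc(C(F)(F)F)cc(C(F)(F)F)c1` gives 8900 nM.
Compound 3 `O=S(=O)(NCCNC(=S)Nc1cc(C(F)(F)F)cc(C(F)(F)F)c1)c1sccc1-c1ccccc1Oc1ccc(O)c(O)c1` gives 7500 nM.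

Compound 2 and compound 3 differ in more than one place, and the difference between their two cores is not broken down here; their two values lie within the scatter of each other. The change from compound 2 to compound 1 is methyl in place of hydrogen on an aromatic carbon. It produced an at least 2.2-fold higher number from compound 2 to compound 1 (0.35 log units; beyond the scatter), the value of compound 1 being (the limit of > 20000 nM in this assay, at which 1 of the 3 values shown sits).

Compound 4 `Cc1ccc(-c2ccsc2S(=O)(=O)NCCNC(=S)Nc2cc(C(F)(F)F)cc(C(F)(F)F)c2)c(Oc2ccc(O)c(O)c2)c1` has not yet been measured. Among the compounds with values here, it differs from compound 3 by methyl in place of hydrogen on an aromatic carbon, the same change at the same place as the one from compound 2 to compound 1. Resting on an at least 2.2-fold higher number from compound 2 to compound 1 (0.35 log units; beyond the scatter), compound 4 is expected to show a 2.7-fold higher number from compound 3 to compound 4 (0.43 log units; beyond the scatter). The estimate for compound 4 is 20000 nM, likely between 10000 nM and 50000 nM, with a real chance that only a limit is reported.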

Compound 4, half-maximal inhibitory concentration: 8000 nM
Beside the measured number, compound 4's estimate is 2.5-fold (0.40 log units) above it; measured number below the stated range.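

On the core of compound 3, methyl in place of hydrogen on an aromatic carbon gave a 1.1-fold higher number from compound 3 to compound 4 (0.03 log units; within the scatter) in this assay, so the two values of this pair lie within the scatter of each other. Set beside the earlier step, this result does not settle whether the change carries from one core to the other: the same change on two cores in this assay, an at least 2.2-fold higher number (0.35 log units; beyond the scatter) from compound 2 to compound 1 and a 1.1-fold higher number (0.03 log units; within the scatter) from compound 3 to compound 4; the limit leaves it open whether they differ. Compound 1 gives > 20000 nM, which is a limit of the assay and not a number, so these two pairs show neither that the step depends on the core nor that it is the same on both: the limit of > 20000 nM in this assay, at which 1 of the 4 values shown sits.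

The compounds shown leave open how the same aromatic carbon would respond to a group other than methyl, such as a chlorine atom, a methoxy group or an amine. Also open, going by these compounds, is whether the methyl step would read the same on a core carrying a carboxylic acid in place of the 3,4-dihydroxyphenoxy group.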